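The source may report more compounds than this note shows. Statements on the series, on what has been measured and on what is new or still open speak of the compounds shown alone.

Measured compounds:
- Compound 1, `COc1cccc(C(=O)N2CCN(CC(=O)N3CCN(CCCc4c[nH]c5ccccc45)CC3)CC2)c1`. In an ADME assay on SH-SY5Y cells (Homo sapiens) for cytotoxicity, read by MTT assay, with a stated time of 72 h (a higher number here means a weaker inhibitor, a lower number a stronger inhibitor), compound 1 gives > 200000 nM, which is a limit of the assay and not a number.
- Compound 2, `O=C(CN1CCN(C(=O)c2cccc(Br)c2)CC1)N1CCN(CCCc2c[nH]c3ccccc23)CC1`. In this assay compound 2 gives 80500 nM.
- Compound 3, `COc1ccc(C(=O)N2CCN(CC(=O)N3CCN(CCCc4c[nH]c5ccc(OC)cc45)CC3)CC2)cc1`. In this assay compound 3 gives 190000 nM.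

Compounds 1 and 2 differ in one place, (bromo in place of methoxy on an aromatic carbon). That change gave an at least 2.4-fold lower number from compound 1 to compound 2 (0.39 log units; beyond the scatter), a step whose size is open on one side since (the limit of > 200000 nM in this assay, at which 1 of the 3 values shown sits). The difference between the core of compound 1 and the core of compound 3 is not broken down here.

Compound 4, `COc1ccc2[nH]cc(CCCN3CCN(C(=O)CN4CCN(C(=O)c5ccc(Br)cc5)CC4)CC3)c2c1`, is not yet measured. It stands to compound 3 as compound 2 stands to compound 1: bromo in place of methoxy on an aromatic carbon. The surroundings are not identical, since in compound 2 the new group sits meta to a large group and in compound 4 it sits para to a large group, so this is the same kind of change rather than the same change.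

From compound 3 to compound 4 a step of about a 2.7-fold lower number from compound 3 to compound 4 (0.43 log units; beyond the scatter) is expected, resting on the size of an at least 2.4-fold lower number from compound 1 to compound 2 (0.39 log units; beyond the scatter). Compound 4 is therefore estimated at 70000 nM, between 30000 nM and 180000 nM.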

Compound 4, half-maximal inhibitory concentration: 150000 nM
Beside the measured number, compound 4's estimate is 2.1-fold (0.33 log units) below it; the measured number falls inside the stated range.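

In this assay, putting bromo in place of methoxy on the core of compound 3 gave a 1.3-fold lower number from compound 3 to compound 4 (0.10 log units; within the scatter), so on this core the change moved the number no more than repeat measurements might, and it is the same kind of change as on the core of compound 1 rather than the very same one. This does not show that the change behaves differently on the two cores, nor that it carries over unchanged: the same change on two cores in this assay, an at least 2.4-fold lower number (0.39 log units; beyond the scatter) from compound 1 to compound 2 and a 1.3-fold lower number (0.10 log units; within the scatter) from compound 3 to compound 4; the limit leaves it open whether they differ. Compound 1 gives > 200000 nM, which is a limit and not a number, so the earlier step has no fixed size to compare with: the limit of > 200000 nM in this assay, at which 1 of the 4 values shown sits.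

The compounds shown offer only methoxy and bromo at this spot, so it remains open whether chloro, a nitrile or an amine there would shift the number in this assay on either core. Also open, on these data alone, is whether a carboxylic acid on the aromatic ring or a longer chain in the linker would give a step that can be read on both cores.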